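The source may report more compounds than this note shows. Statements on the series, on what has been measured and on what is new or still open speak of the compounds shown alone.

Working notes on the series. In a physicochemical assay for lipophilicity (a higher number here means a more lipophilic compound, a lower number a more polar compound), compound 1, `CCN(C1=NCCN1)c1c(Br)cccc1Br`, gives -1.01, the lowest of the three numbers in hand. Compound 2, `C/C=C/CN(C1=NCCN1)c1c(Br)cccc1Br`, gives -0.49, and compound 3, `C=C(C)CCN(C1=NCCN1)c1c(Br)cccc1Br`, gives 0.02. The steps run a number 0.52 log units higher from compound 1 to compound 2 (beyond the scatter), a number 1.03 log units higher from compound 1 to compound 3 (beyond the scatter) and a number 0.51 log units higher from compound 2 to compound 3 (beyond the scatter): each addition of carbon to the chain on the nitrogen raised the number beyond the scatter, and the larger addition raised it more. Compound 4, `Brc1cccc(Br)c1N(Cc1ccccc1)C1=NCCN1`, differs from compound 1 as follows: phenyl in place of methyl on a saturated chain carbon bound to a nitrogen on an aromatic ring. Five more carbons enter as one aromatic ring, more than either earlier addition, so a large upward step in this assay is expected. For compound 4 an estimate of 0.5 is made, within 0 to 1.1. The expected step is a number 1.51 log units higher from compound 1 to compound 4 (beyond the scatter).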

Compound 4, distribution coefficient: -0.05
Estimate against measurement, compound 4: 0.55 log units above, and the stated range ends above it.
By their numbers in this assay, from the lowest: compound 1; then compound 2; then compounds 4 and 3 (each within the scatter of the next).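

In this assay, phenyl in place of methyl at this position gives a number 0.96 log units higher from compound 1 to compound 4 (beyond the scatter), so the number also rises when the added carbon enters as an aromatic ring. Yet compound 4 does not separate from compound 3, a number 0.07 log units lower from compound 3 to compound 4 (within the scatter), while it does separate from compound 2, a number 0.44 log units higher from compound 2 to compound 4 (beyond the scatter), so compound 4 goes against the earlier reading that the larger addition raises the number more. Nothing at hand explains this result.

On these data alone, how a pyridine ring, a cyclohexyl ring or a longer saturated chain would read at this position remains open.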